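Azetidinone series on breast cancer cells: a small change

The source may report more compounds than this note shows. Statements on the series, on what has been measured and on what is new or still open speak of the compounds shown alone.

Compound 1 `COc1cc(N2C(=O)[C@@H](Oc3ccccc3)[C@H]2c2ccc(Br)cc2)cc(OC)c1OC` gives 48000 nM in a functional assay on MCF7 cells (Homo sapiens) for antiproliferative activity, read by MTT assay, with stated times of 24 h and 72 h; a lower number here means a stronger inhibitor, a higher number a weaker inhibitor. Compound 2 `COc1cc(N2C(=O)[C@@H](Oc3ccccc3)[C@H]2c2cccc3ccccc23)cc(OC)c1OC` gives 53000 nM. Compound 3 `COc1ccc(N2C(=O)[C@@H](Oc3ccccc3)[C@H]2c2ccc(OC)c(O)c2)cc1` gives 49000 nM.

Compound 2 sits at the high end of the three numbers, but its neighbours are close: compound 3 lies a little lower and compound 1 a little lower still, both within the scatter, so the three compounds cannot be told apart on these data. Within the data shown here, the one single-point step in the set, a 1.1-fold higher number from compound 1 to compound 2 (0.04 log units; within the scatter), shows that exchanging a 4-bromophenyl for a naphthalen-1-yl on the saturated ring carbon left the number unchanged within the scatter.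

Compound 4 `COc1ccc([C@@H]2[C@H](Oc3ccccc3)C(=O)N2c2cc(OC)c(OC)c(OC)c2)c(N)c1O` differs from compound 2 at that same carbon: a group of 10 heavy atoms (7 carbon, 1 nitrogen, 2 oxygen; one six-membered aromatic ring of carbon only) in place of a group of 10 heavy atoms (10 carbon; 2 six-membered aromatic rings of carbon only), on a saturated ring carbon. Among the measured compounds shown here, no measured step covers this particular exchange. The only bearing is indirect: compound 3, which carries a hydroxyl on its aryl group and a different aryl on the ring nitrogen, gives a number close to that of compound 2. Because a 1.1-fold higher number from compound 1 to compound 2 (0.04 log units; within the scatter) was flat, the account expects that compound 4 will also show no step beyond the scatter, a 1.2-fold lower number from compound 2 to compound 4 (0.07 log units; within the scatter). Compound 4 is therefore estimated at 45000 nM, with a range from 20000 nM to 110000 nM.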

Compound 4, half-maximal inhibitory concentration: 19000 nM
Compound 4: the middle estimate sits 2.4-fold (0.37 log units) above what was measured; the whole stated range lies above it.
By their numbers in this assay, from the lowest: compound 4; then compounds 1, 3 and 2 (each within the scatter of the next).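

The saturated ring carbon next to the ring nitrogen turns out to respond to what it carries: the exchange from 4-bromophenyl to naphthalen-1-yl had been flat, but the group in compound 4, with its nitrogen and two oxygens, gives in this assay both a 2.8-fold lower number from compound 2 to compound 4 (0.45 log units; beyond the scatter) and a 2.5-fold lower number from compound 1 to compound 4 (0.40 log units; beyond the scatter). The entering group and naphthalen-1-yl each have 10 heavy atoms, so a matching heavy-atom count at this position did not give a matching number, and the change that moved the number is one that brings in 2 hydrogen-bond donors and 3 hydrogen-bond acceptors along with a single aromatic ring in place of two. Both steps are modest, and no measurement at hand says why the number fell.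

The compounds shown do not separate the amine, the hydroxyl and the methoxy of the entering group, so it remains open which of them, alone or together, carries the step. Also open, on these data alone, is how this position would respond to a carboxylic acid or to a longer chain ending in an amine.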